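From pyridin-3-yl to pyridin-4-yl on a shared core

A few compounds are considered here, and "the series" means these few. Any claim that something is new, unique, unknown or untested is made for them only; others in the source may bear on it.

Three related compounds have been tested in a physicochemical assay for solubility, in phosphate buffer, with a stated time of 2 h, at pH 7.4; on this read-out higher numbers stand for higher solubility and lower numbers for lower solubility. Compound 1 `Cc1ccc(Nc2nc(-c3ccccn3)cs2)cc1C` gives 20000 nM, and compound 2 `COc1ccc(Nc2nc(-c3ccccn3)cs2)cc1` gives 80000 nM. Going by these compounds, compound 3 `COc1ccc(Nc2nc(-c3cccnc3)cs2)cc1` gives < 10000 nM, which is a limit of the assay and not a number, so its exact position is unknown.

Compound 4 `COc1ccc(Nc2nc(-c3ccncc3)cs2)cc1` differs from compound 3 by pyridin-4-yl in place of pyridin-3-yl on an aromatic carbon. The closest measured change is an at least 8.0-fold lower number from compound 2 to compound 3 (0.90 log units; beyond the scatter), which is pyridin-3-yl in place of pyridin-2-yl and lies beyond the scatter. It ends at the limit of < 10000 nM in this assay, at which 1 of the 3 values shown sits, so it gives a minimum size and not an exact one. Among the compounds with values here, no measured step involves pyridin-4-yl, so no step beyond the scatter in either direction can be expected with confidence. The estimated step is a number no lower from compound 3 to compound 4 (the limit leaves the size open). Compound 4 is expected to give about 10000 nM, with an estimated range from 4000 nM to 40000 nM.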

Compound 4, solubility: 10000 nM
Compound 4: the middle estimate sits on the measured number at the digits printed; the range from low to high includes it.
By their numbers in this assay, from the lowest: compounds 4 and 1 (each within the scatter of the next); then compound 2.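

In this assay, the position on the five-membered ring now has a second measured step away from pyridin-2-yl, and this one has a readable size: an 8.0-fold lower number from compound 2 to compound 4 (0.90 log units; beyond the scatter). Across compounds 2, 3 and 4, the numbers for pyridin-3-yl and pyridin-4-yl both fall short of the number for pyridin-2-yl, so the drop seen with compound 3 is not confined to pyridin-3-yl. The other new step is a number no lower from compound 3 to compound 4 (the limit leaves the size open), and it cannot be read, since one end of it is a limit and not a number: the limit of < 10000 nM in this assay, at which 1 of the 4 values shown sits.

Still open, going by these compounds, is how far compound 3 and compound 4 lie apart, and whether pyridin-4-yl would give a similar step on the core of compound 1. Also open, on these data alone, is what a plain phenyl ring, or a pyridine ring bearing an amine, would give at this position.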